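Aminonicotinonitrile series: phenyl for thiophene in growth inhibition

The compounds below may be only part of what the source reports. "The series", "measured", "known", "first", "only" and "open" are said of these compounds alone.

Measured compounds:
- compound 1 `COc1ccc(-c2cc(-c3cccn3C)c(C#N)c(=O)[nH]2)cc1OC`: 56200 nM
- compound 2 `Cn1cccc1-c1cc(-c2cccs2)nc(N)c1C#N`: > 100000 nM
- compound 3 `COc1ccc(-c2cc(-c3cccn3C)c(C#N)c(N)n2)cc1OC`: 83200 nM

All three were tested in a functional assay on A498 cells (Homo sapiens) for inhibition, read by sulforhodamine B assay, with a stated time of 48 h; on this read-out higher numbers stand for weaker inhibition of growth and lower numbers for stronger inhibition of growth. Compound 1 gives 56200 nM and compound 3 gives 83200 nM; both sit at the weak end of the scale. For compound 2 the value is not a number but a limit of the assay, > 100000 nM, as noted in the limit of > 100000 nM in this assay, at which 1 of the 3 values shown sits. Compound 2 therefore stands at or beyond the weakest reading among the three, and its exact position relative to compound 1 and compound 3 cannot be fixed.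

Compound 4 `Cn1cccc1-c1cc(-c2ccccc2)nc(N)c1C#N` has not yet been measured in this assay. It is made from compound 2 by a single exchange: phenyl in place of thiophen-2-yl on an aromatic carbon. For the measured compounds named here, no measured pair in this set shows the effect of such an exchange, so there is no step to lean on. With compound 2 sitting at a limit, the change from compound 2 to compound 4 is expected to be none beyond the scatter, with the real possibility that compound 4 again returns only a limit.

The expected step is a number no higher from compound 2 to compound 4 (the limit leaves the size open). Compound 4 is estimated at 100000 nM, within a range from 40000 nM to 250000 nM.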

Compound 4, concentration for 50% growth inhibition: 91200 nM
Compound 4: the middle estimate sits 1.1-fold (0.04 log units) above what was measured; the measured number falls inside the stated range.
By their numbers in this assay, from the lowest: compounds 1, 3 and 4 (each within the scatter of the next). At a limit, above all of these: compound 2.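

In this assay compound 4 gives 91200 nM, so with phenyl on this aromatic carbon, next to the ring nitrogen, the read-out returns a number. Compound 2, with thiophen-2-yl at the same place, has no number, only a limit: the limit of > 100000 nM in this assay, at which 1 of the 4 values shown sits.
Going by these compounds, the exchange of thiophen-2-yl for phenyl therefore reads as an at least 1.0-fold lower number from compound 2 to compound 4 (0.04 log units; that floor lies within the scatter), which shows that a carbon-only six-membered ring is tolerated here but supports no claim of a gain beyond the scatter, and the true size of the change remains unknown.

The compounds shown leave open whether another group at this position, such as furan-2-yl, or a phenyl carrying a fluorine atom or a carboxylic acid, would move the number beyond the scatter. For the compounds shown here, this is also the only pair that carries the exchange, so its effect on the core of compound 1 remains open, as does whether any change at this position can lift the series clear of the limit region.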